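Methoxy for Methyl on the Thiadiazole Aryl Ring

This account rests on a few compounds, and the source may have more. Where it says the series, first, only, none or still open, it means among the compounds named here.

Measured compounds: compound 1 `COc1ccc(/C=C/C(=O)Nc2nnc(-c3ccccc3)s2)cc1`, 0.76 ug/mL; compound 2 `Cc1ccc(/C=C/C(=O)Nc2nnc(-c3ccccc3)s2)cc1`, 1.58 ug/mL; compound 3 `Cc1ccc(-c2nnc(NC(=O)/C=C/c3ccccc3)s2)cc1`, 1.38 ug/mL.

In a functional assay on A549 cells (Homo sapiens) for antiproliferative activity, read by MTT assay, with a stated time of 48 h (on this read-out lower numbers stand for stronger inhibition and higher numbers for weaker inhibition), compound 1 gives 0.76 ug/mL and compound 2 gives 1.58 ug/mL. The change from compound 2 to compound 1 is methoxy in place of methyl on an aromatic carbon, and it made the step of a 2.1-fold lower number from compound 2 to compound 1 (0.32 log units; beyond the scatter). Compound 3 gives 1.38 ug/mL in this assay; the difference between the core of compound 3 and that of compound 2 is not broken down here. Compound 4 `COc1ccc(-c2nnc(NC(=O)/C=C/c3ccccc3)s2)cc1` has not been measured. It differs from compound 3 by methoxy in place of methyl on an aromatic carbon, the same change as from compound 2 to compound 1. For the measured compounds named here, because that earlier change gave a 2.1-fold lower number from compound 2 to compound 1 (0.32 log units; beyond the scatter), compound 4 is expected to show a step of about a 1.8-fold lower number from compound 3 to compound 4 (0.26 log units; within the scatter), though with only one prior instance the expectation is loose. Compound 4 is therefore estimated at 0.75 ug/mL, between 0.35 ug/mL and 1.6 ug/mL.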

Compound 4, half-maximal inhibitory concentration: 0.68 ug/mL
Compound 4: the middle estimate sits 1.1-fold (0.04 log units) above what was measured, and the stated range covers the measured number.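

Putting 4-methoxyphenyl in place of 4-methylphenyl on the core of compound 3 gave, in this assay, a 2.0-fold lower number from compound 3 to compound 4 (0.31 log units; beyond the scatter). Set beside the earlier instance on the other core, the change carried over with no difference in size that can be told apart: the same change on two cores in this assay, a 2.1-fold lower number (0.32 log units; beyond the scatter) from compound 2 to compound 1 and a 2.0-fold lower number (0.31 log units; beyond the scatter) from compound 3 to compound 4, 1.0-fold (0.01 log units) apart, within the scatter of two such steps. This rests on two pairs in a single cell assay, so it shows the change carrying over between these two cores only; it does not show why the change acts as it does or that it would hold on any other core.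

The compounds shown leave open whether a chlorine, a dimethylamino group or an ethoxy group in this place would behave like methoxy. They also leave open whether the two methoxy placements, combined in one compound, would add up.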